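Swapping hydroxy for chloro in a cytotoxicity series

The source may hold more compounds than are shown below. What is called first, only, known or untested is meant among the compounds shown, and "the series" means these compounds.

Compound 1 `CCn1cc(C(=O)N2N=C(c3cc4ccccc4o3)CC2c2ccccc2O)c(=O)c2ccc(C)nc21` gives in an ADME assay on Vero cells (Chlorocebus sabaeus) for cytotoxicity, read by MTT assay, with a stated time of 72 h (a lower number here means a stronger inhibitor, a higher number a weaker inhibitor), a limit, > 157000 nM.
Compound 2 `CCn1cc(C(=O)N2N=C(c3cc4ccccc4o3)CC2c2ccc(N(C)C)cc2)c(=O)c2ccc(C)nc21` gives in this assay a limit, > 206000 nM.
Compound 3 `CCn1cc(C(=O)N2N=C(c3cc4ccccc4o3)CC2c2ccc(O)cc2)c(=O)c2ccc(C)nc21` gives in this assay a limit, > 148000 nM.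

Compound 3 therefore stands at a limit, and the two other measured compounds stand at limits as well, so none of the three can be ordered. Compound 4 `CCn1cc(C(=O)N2N=C(c3cc4ccccc4o3)CC2c2ccc(Cl)cc2)c(=O)c2ccc(C)nc21` differs from compound 3 by chloro in place of hydroxy on an aromatic carbon. The measured steps bearing on this region are a step that the two limits leave unreadable from compound 1 to compound 2, a step that the two limits leave unreadable from compound 1 to compound 3 and a step that the two limits leave unreadable from compound 2 to compound 3, none of which can be read in size. On this basis, no step beyond the scatter is expected in this assay. Compound 4 is expected near 150000 nM, within 50000 nM to 500000 nM. The expected step is a step that the limit leaves unreadable from compound 3 to compound 4.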

Compound 4, half-maximal inhibitory concentration: > 160000 nM
Compound 4 gave a limit, no number (the forecaster's own chance of this, stated with the estimate: 80%); middle value at least 1.0-fold (0.02 log units) from the limit.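

Compound 4 gives only a limit in this assay, as do compound 1, compound 2 and compound 3, so no step among these four can be read. From the compounds shown here alone, whether any of these changes on the phenyl group alters cytotoxicity stays open.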